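Notes on replacing carbamoyl with acetamido

The source may report more compounds than this note shows. Statements on the series, on what has been measured and on what is new or still open speak of the compounds shown alone.

Measured so far in a functional assay on A549 cells (Homo sapiens) for inhibition, read by sulforhodamine B assay, with a stated time of 48 h, tested at 50 uM; on this read-out lower numbers stand for less inhibition of growth and higher numbers for more inhibition of growth at the one concentration tested
- compound 1 `COc1ccc([C@@H]2C/C(=N/OCc3cn(-c4ccc(C(=O)c5ccccc5)cc4)nn3)c3cc(CC=C(C)C)c(OC)cc3O2)cc1` gives 34%
- compound 2 `COc1ccc([C@@H]2C/C(=N/OCc3cn(-c4ccccc4CO)nn3)c3cc(CC=C(C)C)c(OC)cc3O2)cc1` gives 100%
- compound 3 `COc1ccc([C@@H]2C/C(=N/OCc3cn(-c4ccc(C(N)=O)cc4)nn3)c3cc(CC=C(C)C)c(OC)cc3O2)cc1` gives 100%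

Compound 3 at 100% shares the top of the three numbers with compound 2 and sits well clear of compound 1. Compound 4 `COc1ccc([C@@H]2C/C(=N/OCc3cn(-c4ccc(NC(C)=O)cc4)nn3)c3cc(CC=C(C)C)c(OC)cc3O2)cc1` has no value yet. It carries acetamido in place of carbamoyl on an aromatic carbon, para to a large group acetamido in place of carbamoyl on an aromatic carbon in the comparison with compound 3.

Among the measured compounds shown here, no measured step makes this exact exchange, so the evidence is indirect. The step of a number 66 percentage points higher from compound 1 to compound 3 (beyond the scatter) is large and comes from amino in place of phenyl on a carbonyl carbon, which shows that a change in this substituent can matter a great deal. The step of no change at the digits printed from compound 2 to compound 3 (within the scatter) lies within the scatter, which shows that two quite different substituents can give the same reading. With compound 3 at the top of the read-out, movement is more likely down than up, and a moderate fall seems the fairest expectation. The expected change is an estimated a number 20 percentage points lower from compound 3 to compound 4 (beyond the scatter) overall. In this assay compound 4 is estimated at 80% with an expected range from 45% to 100% as the likely span.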

Compound 4, percent growth inhibition at one concentration: 19%
The estimate for compound 4 lay 61 percentage points above the measured number; measured number outside the range, below it.
By their numbers in this assay, from the lowest: compound 4; then compound 1; then compounds 2 and 3 (each within the scatter of the next).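

In this assay, acetamido in place of carbamoyl on an aromatic carbon, para to a large group, gives a number 81 percentage points lower from compound 3 to compound 4 (beyond the scatter) and shows that this position does not tolerate every small amide, even though the two groups match in their counted hydrogen-bond donors and acceptors. The same group also separates compound 4 from the other two substituents, with a number 81 percentage points lower from compound 2 to compound 4 (beyond the scatter) on the aromatic nitrogen and a number 15 percentage points lower from compound 1 to compound 4 (beyond the scatter) on the aromatic carbon, so benzoyl no longer marks the low end of the series and the earlier gap between it and carbamoyl is not the full range at this place. No measurement shown here accounts for these falls.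

As far as these compounds go, whether the low reading follows from the acetyl part or from the amide nitrogen sitting directly on the ring remains open, and a plain amine, a carboxylic acid or a longer acyl chain such as propionamido at the same place would help separate the two. With a single tested concentration, the readings also leave open how the compounds would compare over a range of concentrations.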